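A methyl-to-chloro swap in a small cytotoxicity series

This account rests on a few compounds, and the source may have more. Where it says the series, first, only, none or still open, it means among the compounds named here.

Of the compounds shown here, three sharing one core have been tested so far in a functional assay on SK-MEL-28 cells (Homo sapiens) for cytotoxicity, read by CCK-8 assay, with a stated time of 24 h; a higher number here means a weaker inhibitor, a lower number a stronger inhibitor. Compound 1 (`COc1ccccc1Oc1c(N)nc(-c2cccc(C)c2)nc1Cl`) gives 54000 nM, compound 2 (`COc1ccccc1Oc1c(N)nc(Cc2ccccc2)nc1OCCO`) gives 14000 nM, and compound 3 (`COc1ccccc1Oc1c(N)nc(-c2cccc(C)c2)nc1OCCO`) gives 14700 nM. Compound 3 therefore stands level with compound 2, within the scatter of repeated measurements, and well below the number for compound 1.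

The next compound is compound 4 (`COc1ccccc1Oc1c(N)nc(-c2cccc(Cl)c2)nc1OCCO`), which has chloro in place of methyl on an aromatic carbon, so that 3-methylphenyl becomes 3-chlorophenyl: chloro in place of methyl on an aromatic carbon. Among the measured compounds shown here, no measured pair makes this exact swap, so the evidence is indirect. Putting 2-hydroxyethoxy in place of chloro on an aromatic carbon gave a 3.7-fold lower number from compound 1 to compound 3 (0.57 log units; beyond the scatter), a modest step, but that change lies elsewhere in the molecule and says little here. Closer to the point, 3-methylphenyl in place of benzyl gave a 1.1-fold higher number from compound 2 to compound 3 (0.02 log units; within the scatter), so replacing the whole group at this site moved the number by no more than the scatter.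

No step beyond the scatter is therefore expected in this assay, and the expected step is a 1.2-fold lower number from compound 3 to compound 4 (0.09 log units; within the scatter). For compound 4 the estimated value is 12000 nM, with an expected range from 6000 nM to 25000 nM.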

Compound 4, half-maximal inhibitory concentration: 4170 nM
The estimate for compound 4 lay 2.9-fold (0.46 log units) above the measured number; the measured number lies below the stated range.
By their numbers in this assay, from the lowest: compound 4; then compounds 2 and 3 (each within the scatter of the next); then compound 1.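

Exchanging methyl for chloro, one heavy atom for one, gives a 3.5-fold lower number from compound 3 to compound 4 (0.55 log units; beyond the scatter) in this assay, so the substituent on this aromatic ring can shift the number beyond the scatter. The earlier compounds shown here did not show this: 3-methylphenyl and benzyl stood level in compound 2 and compound 3, which made the site look unresponsive, whereas 3-chlorophenyl in place of benzyl gives a 3.4-fold lower number from compound 2 to compound 4 (0.53 log units; beyond the scatter) and separates compound 4 from both. The two groups have the same counts of heavy atoms, hydrogen-bond donors and hydrogen-bond acceptors and carry no net charge, so those counts do not distinguish them, and no measurement of any other property is available to account for the step.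

Going by these compounds, only methyl and chloro can be compared directly on this ring, so it remains open whether fluoro, bromo, methoxy or a nitrile would lower the number further or raise it again. On these data alone, it is also open whether the gain from chloro would carry over if the 2-hydroxyethoxy chain of compound 4 gave way to a longer chain, an amine or a carboxylic acid.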